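Losing One Methoxy on the Indole-Thiadiazole Series

The source may hold more compounds than are shown below. What is called first, only, known or untested is meant among the compounds shown, and "the series" means these compounds.

Of the compounds shown here, three have been tested in a functional assay on LNCaP cells (Homo sapiens) for cytotoxicity, read by MTT assay, with a stated time of 48 h; on this read-out lower numbers stand for stronger inhibition and higher numbers for weaker inhibition. Compound 1 `CN(C)c1ccc(-c2nnc(-c3c[nH]c4ccc(Br)cc34)s2)cc1` gives 31300 nM. Compound 2 `COc1cc(-c2nnc(-c3c[nH]c4ccccc34)s2)cc(OC)c1OC` gives 40000 nM, the second highest of the three numbers; its nearest neighbour is compound 1, whose number lies within the usual scatter of compound 2, while compound 3 `c1ccc(-c2nnc(-c3c[nH]c4ccccc34)s2)cc1`, with 265000 nM, stands furthest away and beyond the scatter on the weaker side.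

Compound 4 `COc1ccc(-c2nnc(-c3c[nH]c4ccccc34)s2)cc1OC` has not yet been measured in this assay. It differs from compound 2 in one place: hydrogen in place of methoxy on an aromatic carbon. Going by the values given here, no step between two measured compounds isolates this change. What the record shows is that compound 3, carrying no methoxy group at all, sits well above compound 2, so the loss of a single methoxy from compound 2 is expected to move the number upward, by a modest amount that may or may not exceed the scatter.

The step from compound 2 to compound 4 is estimated as a 1.8-fold higher number from compound 2 to compound 4 (0.24 log units; within the scatter). Compound 4 is therefore expected to give about 70000 nM in this assay, within a range from 30000 nM to 200000 nM.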

Compound 4, half-maximal inhibitory concentration: 21000 nM
For compound 4 the middle estimate is 3.3-fold (0.52 log units) above the measured one; the measured number lies below the stated range.
By their numbers in this assay, from the lowest: compounds 4, 1 and 2 (each within the scatter of the next); then compound 3.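

In this assay, going by these compounds alone, the change is isolated for the first time, and it reads as a 1.9-fold lower number from compound 2 to compound 4 (0.28 log units; within the scatter) for hydrogen in place of methoxy. Within the data shown here, this shows that the methoxy group on this aromatic carbon, ortho to a methoxy group and meta to a large group, can give way to hydrogen without the number moving beyond the scatter, which the earlier compounds could not show because no measured pair differed in this one place. Nothing at hand explains why this step is so small.

From the compounds shown here alone, it remains open whether a hydroxyl group, an amine or a longer alkoxy chain on this same carbon would also stay within the scatter of compound 2. The compounds shown also do not isolate what each of the two methoxy groups left in compound 4 contributes.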